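The compounds below may be only part of what the source reports. "The series", "measured", "known", "first", "only" and "open" are said of these compounds alone.

Three compounds share one core and differ only in the ring attached to an aromatic carbon of a six-membered aromatic ring of carbon only. Compound 1 `CCC(C)(C)Cc1c[nH]c(CCc2ccc(-n3ccnn3)cc2)n1` gives 93 nM in a functional assay on HEK293 cells for agonist activity at Bombesin receptor subtype-3 (Homo sapiens), read by luminescence and calcium flux, with a stated time of 10 min; a lower number here means that less compound is needed, a higher number that more compound is needed for the effect. Compound 2 `CCC(C)(C)Cc1c[nH]c(CCc2ccc(-c3cnccn3)cc2)n1` gives 100 nM, and compound 3 `CCC(C)(C)Cc1c[nH]c(CCc2ccc(-c3ccc(F)cn3)cc2)n1` gives 97 nM. Compound 2 sits alongside both neighbours: a 1.1-fold higher number from compound 1 to compound 2 (0.03 log units; within the scatter) and a 1.0-fold lower number from compound 2 to compound 3 (0.01 log units; within the scatter), so the three numbers are indistinguishable. Compound 4 `CCC(C)(C)Cc1c[nH]c(CCc2ccc(-c3ccns3)cc2)n1` is not yet measured; it carries 1,2-thiazol-5-yl in place of pyrazin-2-yl on an aromatic carbon. For the measured compounds named here, the steps that bear on this swap are a 1.1-fold higher number from compound 1 to compound 2 (0.03 log units; within the scatter), a 1.0-fold higher number from compound 1 to compound 3 (0.02 log units; within the scatter) and a 1.0-fold lower number from compound 2 to compound 3 (0.01 log units; within the scatter), each within the scatter, so exchanging one small aromatic ring for another has so far left the number unchanged. No step beyond the scatter is therefore expected, meaning no change at the digits printed from compound 2 to compound 4 (within the scatter). Compound 4 is estimated at 100 nM, with a range from 50 nM to 200 nM.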

Compound 4, half-maximal effective concentration: 102 nM
Estimate against measurement, compound 4: 1.0-fold (0.01 log units) below, and the stated range covers the measured number.
By their numbers in this assay, from the lowest: compounds 1, 3, 2 and 4 (each within the scatter of the next).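

The 1,2-thiazol-5-yl ring brings the first sulfur atom to this position, on an aromatic carbon para to a large group, yet the number in this assay does not move beyond the scatter: a 1.0-fold higher number from compound 2 to compound 4 (0.01 log units; within the scatter), a 1.1-fold higher number from compound 3 to compound 4 (0.02 log units; within the scatter) and a 1.1-fold higher number from compound 1 to compound 4 (0.04 log units; within the scatter). Five-membered and six-membered aromatic rings attached here have now given matching numbers across all four compounds. Nothing shown explains why these rings match. As far as these compounds go, all four groups are aromatic rings, so what an amine, a carboxylic acid or a longer chain would do at this position remains open.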